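The compounds below may be only part of what the source reports. "The series", "measured", "known", "first", "only" and "open" are said of these compounds alone.

Going by the values given here, compound 3 `NC(=O)CSCc1nc2cc([N+](=O)[O-])ccc2[nH]1` is one of three compounds measured in a functional assay on HepG2 cells (Homo sapiens) for cytotoxicity, read by MTT assay, with a stated time of 48 h; on this read-out higher numbers stand for weaker inhibition and lower numbers for stronger inhibition. Compound 1 `O=C(CSCc1nc2cc([N+](=O)[O-])ccc2[nH]1)c1ccccc1` gives 16100 nM in this assay, and compound 2 `O=C(CSCc1nc2cc([N+](=O)[O-])ccc2[nH]1)c1ccc(Br)cc1` gives 2010 nM. Compound 3 gives 26900 nM in this assay, the highest of the three numbers: the step of a 1.7-fold higher number from compound 1 to compound 3 (0.22 log units; within the scatter) stays within the scatter, whereas the step of a 13-fold higher number from compound 2 to compound 3 (1.13 log units; beyond the scatter) lies beyond it. The step of an 8.0-fold lower number from compound 1 to compound 2 (0.90 log units; beyond the scatter) shows that the bromo group on the aromatic carbon made the strongest difference among the measured compounds.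

Compound 4 `NNC(=O)CSCc1nc2cc([N+](=O)[O-])ccc2[nH]1` differs from compound 3 in one place: amino in place of hydrogen on an amide-type nitrogen. Among the compounds with values here, no measured step repeats this change on the amide-type nitrogen; the steps from compound 1 and compound 2 to compound 3 concern the carbonyl carbon and its substituent, which compound 4 keeps as a carbamoyl group. On the evidence shown, no step beyond the scatter is expected, and the expected step of a 1.1-fold lower number from compound 3 to compound 4 (0.03 log units; within the scatter) is small. Compound 4 is therefore estimated at 25000 nM in this assay, within a range from 10000 nM to 65000 nM.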

Compound 4, half-maximal inhibitory concentration: 18600 nM
Compound 4: middle estimate off by 1.3-fold (0.13 log units), on the high side; the measured number falls inside the stated range.
By their numbers in this assay, from the lowest: compound 2; then compounds 1, 4 and 3 (each within the scatter of the next).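

In this assay, going by these compounds alone, the step of a 1.4-fold lower number from compound 3 to compound 4 (0.16 log units; within the scatter) stays within the scatter, giving the first reading at the amide-type nitrogen: carbamoyl to aminocarbamoyl leaves no difference that can be told from repeat variation. The step of a 1.2-fold higher number from compound 1 to compound 4 (0.06 log units; within the scatter) is also within the scatter, whereas the step of a 9.3-fold higher number from compound 2 to compound 4 (0.97 log units; beyond the scatter) lies beyond it, so among these four compounds the 4-bromophenyl on the carbonyl carbon remains the only group that sets a compound apart. The data shown offer no measured evidence that explains these results.

Going by these compounds, whether a methyl or an acetyl group on the added amino would give a step beyond the scatter remains open. So does whether a 4-bromophenyl carried on that amino would bring the number close to that of compound 2.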